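Cyanoguanidine in place of thiourea on the pyridazinone series

The source may report more compounds than this note shows. Statements on the series, on what has been measured and on what is new or still open speak of the compounds shown alone.

Compounds measured so far:
compound 1 `O=c1ccc(-c2ccccc2)nn1CCCCNC(=S)NC1CCCCC1`, 18.1%
compound 2 `O=c1ccc(-c2ccccc2)nn1CCCCNC(=S)NCc1ccccc1`, 5.4%

In a functional assay on the whole organism with Rattus norvegicus as the target, at a dose of 100 mg/kg (a lower number here means less inhibition, a higher number more inhibition at the dose given (going by the name of the read-out)), compound 1 gives 18.1%, the highest of the two numbers; compound 2 gives 5.4% in this assay. Going by the values given here, the one step known, a number 12.7 percentage points lower from compound 1 to compound 2 (beyond the scatter), does not touch the part that changes now. Compound 3 `CCC/N=C(/NC#N)NCCCCn1nc(-c2ccccc2)ccc1=O` differs from compound 1 by a group of 8 heavy atoms (5 carbon, 3 nitrogen; no ring) in place of a group of 9 heavy atoms (7 carbon, 1 nitrogen, 1 sulfur; one six-membered non-aromatic ring of carbon only), on an amine nitrogen. Among the compounds with values here, no measured step bears on this change, so the estimate rests on both measured values being low: a step of a number 8.1 percentage points lower from compound 1 to compound 3 (within the scatter) is expected, and compound 3 is estimated at 10%, within -5% to 25%.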

Compound 3, a percentage reported as inhibition, in the whole organism at one dose (the size of the read-out at that dose, not a potency): 26.3%
Compound 3: middle estimate off by 16.3 percentage points, on the low side, outside the stated range (above it).
By their numbers in this assay, from the lowest: compound 2; then compounds 1 and 3 (each within the scatter of the next).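

On the amine nitrogen, the group of 8 heavy atoms with no ring and the group of 9 heavy atoms with its six-membered ring stand level in this assay: the step is a number 8.2 percentage points higher from compound 1 to compound 3 (within the scatter), so this pair shows that neither the sulfur nor that ring is needed for a reading of this size. Nothing measured on the series accounts for this result.

Still open, on these data alone, is how a cyclohexyl, a benzyl or a longer chain on the cyanoguanidine would read in this assay, and whether the benzyl step seen with the thioureas carries over.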